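Chloro for hydrogen on the aromatic ring: paired steps

The source may hold more compounds than are shown below. What is called first, only, known or untested is meant among the compounds shown, and "the series" means these compounds.

Measured compounds, with values in a functional assay on NCI-H460 cells (Homo sapiens) for inhibition, read by MTT assay, with a stated time of 24 h, tested at 0.1 ug/mL; a higher number here means more inhibition of growth at the concentration tested, a lower number less inhibition of growth:
compound 1 `O=C(CCCCC1CCSS1)Nc1ccccn1` gives 2.61%
compound 2 `O=C(CCCCC1CCSS1)Nc1ccc(Cl)cn1` gives 3.93%
compound 3 `O=C(CCCCC(S)CCS)Nc1ccccc1` gives 5.5%

All three numbers sit close together, and none of the gaps between them passes the usual scatter. Within the data shown here, the one counted step is chloro in place of hydrogen on an aromatic carbon, which made a number 1.3 percentage points higher from compound 1 to compound 2 (within the scatter). Compound 4 `O=C(CCCCC(S)CCS)Nc1ccccc1Cl` is not yet measured; it differs from compound 3 by chloro in place of hydrogen on an aromatic carbon. The difference between the core of compound 1 and the core of compound 3 is not broken down here. The two chloro steps are the same kind of change, not the same: in compound 2 the chloro sits on a ring with one nitrogen, two atoms from the ring nitrogen, para to a large group, whereas in compound 4 it sits on a ring of carbon only, ortho to a large group. Since the step from compound 1 to compound 2 stayed within the scatter, a similar small shift is expected from compound 3 to compound 4, namely a number 1 percentage points higher from compound 3 to compound 4 (within the scatter). Compound 4 is therefore estimated at 6.5% in this assay, between 0% and 15%.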

Compound 4, percent growth inhibition at one concentration: 6.36%
The estimate for compound 4 lay 0.1 percentage points above the measured number; low and high end bracket the measured number.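

In this assay chloro in place of hydrogen on an aromatic carbon gave a number 0.9 percentage points higher from compound 3 to compound 4 (within the scatter) and the step carries across the two cores without a detectable difference: the same change on two cores in this assay, a number 1.3 percentage points higher (within the scatter) from compound 1 to compound 2 and a number 0.9 percentage points higher (within the scatter) from compound 3 to compound 4, 0.5 percentage points apart, within the scatter of two such steps. Among these compounds, this shows only that the change stayed within the scatter on both cores, not that it raises growth inhibition on either. The chloro also sits in a different place on a different ring in the two pairs, and a single tested concentration cannot show whether the agreement holds elsewhere.

Still open, from the compounds shown here alone, is whether bromo, methoxy or an amine in place of the chloro would move the number beyond the scatter on either core. Also open, going by these compounds, is what a longer chain between the amide and the sulfur atoms would do.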